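The source may hold more compounds than are shown below. What is called first, only, known or untested is meant among the compounds shown, and "the series" means these compounds.

Compounds measured so far in a functional assay on the whole organism (strain Wistar) with Rattus norvegicus as the target, read by paw edema; on this read-out lower numbers stand for an effect already at smaller amounts and higher numbers for an effect only at larger amounts of compound
- compound 1 `CCC(=O)NS(=O)(=O)c1ccc(-n2nc(C(F)(F)F)cc2-c2ccc(Br)cc2)cc1CO` (7.2 mg/kg)
- compound 2 `CCC(=O)NS(=O)(=O)c1ccc(-n2nc(C(F)F)cc2-c2ccc(Br)cc2)cc1COC(=O)CC` (7.9 mg/kg)
- compound 3 `CCC(=O)NS(=O)(=O)c1ccc(-n2nc(C(F)F)cc2-c2ccc(Br)cc2)cc1CO` (5.6 mg/kg)

Going by the values given here, compound 3 stands within the scatter of both others, with a 1.3-fold lower number from compound 1 to compound 3 (0.11 log units; within the scatter) and a 1.4-fold lower number from compound 2 to compound 3 (0.15 log units; within the scatter) as its only measured steps. Compound 4 `CCC(=O)NS(=O)(=O)c1ccc(-n2nc(C(F)F)cc2-c2ccc(OC)c(C)c2)cc1CO` differs from compound 3 by 4-methoxy-3-methylphenyl in place of 4-bromophenyl on an aromatic carbon in one place: 4-methoxy-3-methylphenyl in place of 4-bromophenyl on an aromatic carbon. Among the compounds with values here, neither measured step touches the 4-bromophenyl group, so the data hold no direct precedent for this exchange and give no direction. Accordingly, a 1.1-fold higher number from compound 3 to compound 4 (0.03 log units; within the scatter) is the estimated step in this assay and no change beyond the scatter is expected. For compound 4 the estimated value is 6 mg/kg with an expected range from 2.8 mg/kg to 13 mg/kg in this estimate.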

Compound 4, dose for half-maximal effect: 6.3 mg/kg
The estimate for compound 4 lay 1.1-fold (0.02 log units) below the measured number, and the stated range covers the measured number.
By their numbers in this assay, from the lowest: compounds 3, 4, 1 and 2 (each within the scatter of the next).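

Going by these compounds alone, the exchange of 4-bromophenyl for 4-methoxy-3-methylphenyl gives a 1.1-fold higher number from compound 3 to compound 4 (0.05 log units; within the scatter) in this assay and is the first measured step at this aromatic carbon next to the ring nitrogen. It shows that the bromine can be replaced by a methoxy and a methyl group, adding a hydrogen-bond acceptor, with no change beyond the scatter. No measurement here accounts for this result.

From the compounds shown here alone, whether the methoxy or the methyl group alone would give the same result remains open, as does the effect of a carboxylic acid or an amine on this phenyl ring.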